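The source may hold more compounds than are shown below. What is called first, only, known or untested is meant among the compounds shown, and "the series" means these compounds.

Measured compounds:
- Compound 1, `COc1cccc(-c2csc(N/N=C/c3ccco3)n2)c1`: 6780 nM
- Compound 2, `CCCCC/C(C)=N/Nc1nc(-c2cccc(OC)c2)cs1`: 6720 nM

Of the compounds shown here, two sharing one core have been measured in an assay on isolated protein for inhibition of Amine oxidase [flavin-containing] B (Homo sapiens), read by fluorescence; a higher number here means a weaker inhibitor, a lower number a stronger inhibitor. Compound 1 gives 6780 nM, and compound 2 gives 6720 nM; the two numbers lie within the scatter of each other, so neither can be told apart from the other on these data. Compound 3, `CCC/C(C)=N/Nc1nc(-c2cccc(OC)c2)cs1`, has not yet been measured in this assay. It differs from compound 1 in one place: a group of 6 heavy atoms (5 carbon, 1 nitrogen; no ring) in place of a group of 7 heavy atoms (5 carbon, 1 nitrogen, 1 oxygen; one five-membered aromatic ring with 1 hetero atom), on a nitrogen on an aromatic ring. Among the measured compounds shown here, no step between measured compounds exists to size this change against; only the pair of values above, which sit together, is available. The step of a 1.0-fold higher number from compound 1 to compound 3 (0.01 log units; within the scatter) is therefore expected to be small, with no direction beyond the scatter. For compound 3 in this assay the estimate is 7000 nM, with a range from 2500 nM to 20000 nM.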

Compound 3, half-maximal inhibitory concentration: 871 nM
Compound 3: the middle estimate sits 8.0-fold (0.91 log units) above what was measured; the whole stated range lies above it.
By their numbers in this assay, from the lowest: compound 3; then compounds 2 and 1 (each within the scatter of the next).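

The group on a nitrogen on an aromatic ring proves able to move the number in this assay: the open chain with no ring, in place of the five-membered aromatic ring with 1 hetero atom, gives a 7.8-fold lower number from compound 1 to compound 3 (0.89 log units; beyond the scatter). Chain length also counts, which the first two values, within the scatter of each other, gave no sign of: hydrogen in place of ethyl on a saturated chain carbon, three bonds along the chain from a carbon with a double bond to nitrogen, gives a 7.7-fold lower number from compound 2 to compound 3 (0.89 log units; beyond the scatter). No supporting data bear on what lies behind either step.

The compounds shown leave open whether a still shorter chain or a branched chain would lower the number further. They also leave open how a chain ending in an amine or a saturated ring such as cyclohexyl would read at this place.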